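Oxygen to sulfur in a small ring beside the sulfonyl

This account rests on a few compounds, and the source may have more. Where it says the series, first, only, none or still open, it means among the compounds named here.

Measured so far:
- compound 1, `O=S(=O)(CC1=NCCO1)c1c(-c2ccccc2)nn(-c2ccccc2)c1-c1ccccc1`, gives 55.6%
- compound 2, `COc1ccc(C2=NOC(c3ccc(C)cc3)C2S(=O)(=O)CC2=NCCO2)cc1`, gives 65.9%

Both numbers come from a functional assay, tested at 50 ug/mL; on this read-out lower numbers stand for a weaker effect and higher numbers for a stronger effect at the one concentration tested. Compound 1 is the lower of the two, and compound 2 sits higher by an amount beyond the usual scatter. For the measured compounds named here, no pair of measured compounds differs in only one place, so no single structural change has yet been tied to a change in the read-out.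

Compound 3, `O=S(=O)(CC1=NCCS1)c1c(-c2ccccc2)nn(-c2ccccc2)c1-c1ccccc1`, is not yet measured. It differs from compound 1 by a group of 5 heavy atoms (3 carbon, 1 nitrogen, 1 sulfur; one five-membered non-aromatic ring with 2 hetero atoms) in place of a group of 5 heavy atoms (3 carbon, 1 nitrogen, 1 oxygen; one five-membered non-aromatic ring with 2 hetero atoms), on a saturated chain carbon bound to a sulfonyl sulfur. Nothing measured here speaks to this kind of exchange, so the step is expected to be modest: a number 1.4 percentage points higher from compound 1 to compound 3 (within the scatter), most likely within the scatter and with no clear direction. Compound 3 is therefore expected to give about 57% in this assay, with a range from 40% to 74%.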

Compound 3, a percentage reported as activity, at one concentration (the size of the read-out at that concentration, not a potency): "not active" (no number reported)
No number was reported for compound 3; the estimate stays without a comparison.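

For the compounds shown here, compound 3 is reported as "not active" in this assay with no number, so no step from compound 1 can be read. Nothing available explains this result. The compounds shown leave open how far the sulfur-containing ring lowers the read-out relative to the oxygen-containing ring.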